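Cyclohexylmethyl ether variant of the shared core in cytotoxicity

The source may hold more compounds than are shown below. What is called first, only, known or untested is meant among the compounds shown, and "the series" means these compounds.

Compound 1 `CCC(C)Oc1ccc(C(O)C2OC(=O)c3c(OC)cc(OC)cc32)cc1` is the point of departure. In an ADME assay on RAW264.7 cells (Mus musculus) for cytotoxicity, read by MTT assay, with a stated time of 24 h, in the absence of a further agent (on this read-out higher numbers stand for weaker inhibition and lower numbers for stronger inhibition), compound 1 gives > 40000 nM, which is a limit of the assay and not a number. Compound 2 `COc1cc(OC)c2c(c1)C(C(O)c1ccc(OCc3ccc(F)cc3)cc1)OC2=O` carries a 4-fluorobenzyl in place of sec-butyl on an oxygen on an aromatic ring; in this assay compound 2 gives > 40000 nM, again only a limit. Compound 3 `COc1cc(OC)c2c(c1)C(C(O)c1ccc(OCc3ccc(Br)cc3)cc1)OC2=O` carries a 4-bromobenzyl at that oxygen; in this assay compound 3 gives > 40000 nM, also a limit. The steps a step that the two limits leave unreadable from compound 1 to compound 2, a step that the two limits leave unreadable from compound 1 to compound 3 and a step that the two limits leave unreadable from compound 2 to compound 3 therefore carry no readable size, because of the limit of > 40000 nM in this assay, at which 3 of the 3 values shown sit. Compound 4 `COc1cc(OC)c2c(c1)C(C(O)c1ccc(OCC3CCCCC3)cc1)OC2=O` differs from compound 1 as follows: cyclohexylmethyl in place of sec-butyl on an oxygen on an aromatic ring. For the measured compounds named here, no measured step has a readable size, so the measured steps give neither a direction nor a magnitude for this change. Compound 4 is expected to sit at the same limit, so the expected step is a number no higher from compound 1 to compound 4 (the limit leaves the size open). The estimate for compound 4 is 40000 nM, expected within the range 20000 nM to 100000 nM.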

Compound 4, half-maximal inhibitory concentration: > 40000 nM
Compound 4: only a limit was reported; the forecaster's own chance of this, stated with the estimate: 85%; the middle value lies on the limit itself.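

For the compounds shown here, no step linking compound 4 with compound 1, compound 2 or compound 3 can be read, because all four compounds share one limit of the assay: the limit of > 40000 nM in this assay, at which 4 of the 4 values shown sit. The compounds shown leave open whether any of these ether groups changes the cytotoxicity of the shared core, and in which direction.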